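The source may hold more compounds than are shown below. What is called first, only, known or untested is meant among the compounds shown, and "the series" means these compounds.

In a functional assay on MCF7 cells (Homo sapiens) for inhibition, read by sulforhodamine B assay (a lower number here means a stronger inhibitor, a higher number a weaker inhibitor), compound 1 `Cc1ccc(NC2=CC(=O)c3nc4n(c3C2=O)[C@H]2OC[C@@H](O)[C@H]2OC4)cc1C` gives 2080 nM, and compound 2 `CCc1ccc(NC2=CC(=O)c3nc4n(c3C2=O)[C@H]2OC[C@@H](O)[C@H]2OC4)cc1` gives 960 nM. Compound 3 `O=C1C=C(N2CCCCC2)C(=O)c2c1nc1n2[C@H]2OC[C@@H](O)[C@H]2OC1` gives no number but only a limit of the assay, > 8000 nM, as told by the limit of > 8000 nM in this assay, at which 1 of the 3 values shown sits. Compound 3 therefore stands at the weak end of the three, since there is an at least 3.8-fold higher number from compound 1 to compound 3 (0.58 log units; beyond the scatter) and an at least 8.3-fold higher number from compound 2 to compound 3 (0.92 log units; beyond the scatter). Both of these steps swap an arylamino group for piperidin-1-yl on the shared core, and both raise the number.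

Compound 4 `O=C1C=C(Nc2ccc(Br)cc2)C(=O)c2c1nc1n2[C@H]2OC[C@@H](O)[C@H]2OC1` differs from compound 3 by (4-bromophenyl)amino in place of piperidin-1-yl on a double-bonded ring carbon. This change runs the other way from those two steps, restoring an arylamino group, so a clearly lower number is expected for compound 4, an at least 5.3-fold lower number from compound 3 to compound 4 (0.72 log units; beyond the scatter). The estimate for compound 4 is 1500 nM, with a range from 500 nM to 5000 nM.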

Compound 4, half-maximal inhibitory concentration: 2580 nM
Compound 4: middle estimate off by 1.7-fold (0.24 log units), on the low side; the measured number falls inside the stated range.
By their numbers in this assay, from the lowest: compound 2; then compounds 1 and 4 (each within the scatter of the next). At a limit, above all of these: compound 3.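

A third arylamino group, (4-bromophenyl)amino, also reads better than piperidin-1-yl on this double-bonded ring carbon (an at least 3.1-fold lower number from compound 3 to compound 4 (0.49 log units; beyond the scatter)), and that size is only a bound, since the value of compound 3 is a limit: the limit of > 8000 nM in this assay, at which 1 of the 4 values shown sits. Among the arylamino groups, bromo in place of ethyl gives a 2.7-fold higher number from compound 2 to compound 4 (0.43 log units; beyond the scatter), so the group on the aromatic ring matters, while 4-bromophenyl in place of 3,4-dimethylphenyl gives a 1.2-fold higher number from compound 1 to compound 4 (0.09 log units; within the scatter). Still open, as far as these compounds go, is whether the aromatic ring or the amine hydrogen carries the difference from piperidin-1-yl. A benzylamino group or a methoxy on the phenyl ring would extend the comparison.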